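The source may report more compounds than this note shows. Statements on the series, on what has been measured and on what is new or still open speak of the compounds shown alone.

Working notes on the sulfonamide series.

Compound 2 `CC1(C)C=C(n2ccccc2=O)c2cc(S(=O)(=O)NCc3ccccc3)ccc2O1` gives 77.5% in a functional assay on the whole organism (trachea) with Rattus norvegicus as the target (a lower number here means a smaller maximal response, a higher number a larger maximal response), the lower of the two numbers on hand. Compound 1 `CCNS(=O)(=O)c1ccc2c(c1)C(n1ccccc1=O)=CC(C)(C)O2` gives 87%; the step of a number 9.5 percentage points lower from compound 1 to compound 2 (within the scatter) lies within the scatter. Compound 3 `CC1(C)C=C(n2ccccc2=O)c2cc(S(=O)(=O)Nc3ccccc3)ccc2O1` has two entries, 7.85%; 88% (2 entries) (the several entries of compound 3 in this assay, 7.85%; 88% (2 entries)), and so yields no single number.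

Compound 4 `CC1(C)C=C(n2ccccc2=O)c2cc(S(=O)(=O)Nc3ccc(C#N)cc3)ccc2O1` differs from compound 2 by 4-cyanophenyl in place of benzyl on a sulfonamide nitrogen. For the measured compounds named here, no measured step covers this change; the one measured step, phenyl in place of methyl on a saturated chain carbon bound to a sulfonamide nitrogen, stayed within the scatter, while compound 3 carries phenyl directly on the sulfonamide nitrogen and its two entries sit far apart. For compound 4 a step of a number 7.5 percentage points lower from compound 2 to compound 4 (within the scatter) in this assay is expected, with a wide range owing to the spread of compound 3. Compound 4 is estimated at 70%, between 30% and 95%.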

Compound 4, largest response reached (Emax), in percent of the reference or control that the assay uses: 90.8%
The estimate for compound 4 lay 20.8 percentage points below the measured number; low and high end bracket the measured number.
By their numbers in this assay, from the lowest: compounds 2, 1 and 4 (each within the scatter of the next, the first and the last beyond it).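

In this assay, the sulfonamide nitrogen now shows a step beyond the scatter: 4-cyanophenyl in place of benzyl gives a number 13.3 percentage points higher from compound 2 to compound 4 (beyond the scatter). The change from ethyl to 4-cyanophenyl on the same nitrogen gives a number 3.8 percentage points higher from compound 1 to compound 4 (within the scatter), so those two groups are not separated, and this position has so far shown only a modest difference among compounds with a single number.

Compound 3, with phenyl on that nitrogen, cannot show what the nitrile adds: the several entries of compound 3 in this assay, 7.85%; 88% (2 entries). Going by these compounds, what a carboxylic acid or an amine-bearing chain on that nitrogen would give remains open.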